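Shifting the trifluoromethyl on the benzamide of compound 2

The compounds below may be only part of what the source reports. "The series", "measured", "known", "first", "only" and "open" are said of these compounds alone.

Measured so far:
Compound 1, `Nc1ccc(C(=O)Nc2nc(-c3ccccc3)nc3c2nnn3Cc2ccccc2)cc1`: 926 nM
Compound 2, `O=C(Nc1nc(-c2ccccc2)nc2c1nnn2Cc1ccccc1)c1ccc(C(F)(F)F)cc1`: 4210 nM

In an assay on CHO cells for displacement of a labelled ligand from adenosine receptor A3 (Homo sapiens), read by scintillation counting (a higher number here means a weaker inhibitor, a lower number a stronger inhibitor), compound 2 stands highest of the two numbers, with compound 1 nearest below it; the change from compound 1 to compound 2 was a 4.5-fold higher number from compound 1 to compound 2 (0.66 log units; beyond the scatter). Compound 3, `O=C(Nc1nc(-c2ccccc2)nc2c1nnn2Cc1ccccc1)c1cccc(C(F)(F)F)c1`, carries 3-(trifluoromethyl)phenyl in place of 4-(trifluoromethyl)phenyl on a carbonyl carbon. Among the measured compounds shown here, no measured step swaps the position of a group in this way, so that step gives no direct guide. Compound 3 is therefore expected near compound 2, the step of a 1.4-fold lower number from compound 2 to compound 3 (0.15 log units; within the scatter). The estimate for compound 3 is 3000 nM, within 800 nM to 12000 nM.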

Compound 3, inhibition constant: 2510 nM
Compound 3: the middle estimate sits 1.2-fold (0.08 log units) above what was measured, within the range that was stated.
By their numbers in this assay, from the lowest: compound 1; then compounds 3 and 2 (each within the scatter of the next).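

In this assay, moving the trifluoromethyl from 4-(trifluoromethyl)phenyl to 3-(trifluoromethyl)phenyl on the carbonyl carbon gives a 1.7-fold lower number from compound 2 to compound 3 (0.22 log units; within the scatter) and so stays inside what repeat measurements would show. The 4-aminophenyl group keeps its lower number against this placement as well, with a 2.7-fold higher number from compound 1 to compound 3 (0.43 log units; beyond the scatter) beyond the scatter, so the rise seen on leaving the amino group holds for both trifluoromethyl placements. Nothing at hand explains either step.
On these data alone, whether a nitrile or a carboxylic acid on that ring would read closer to compound 1 remains open.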